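Swapping the Aryl Ring: Solubility of a Thiazole Analogue

The compounds below may be only part of what the source reports. "The series", "measured", "known", "first", "only" and "open" are said of these compounds alone.

Measured compounds:
- Compound 1 `Cc1ccc(Cn2c(=O)[nH]c3c(N)nc(C(F)(F)F)cc32)cn1`: 22 ug/mL
- Compound 2 `Cc1ncc(Cn2c(=O)[nH]c3c(N)nc(C(F)(F)F)cc32)cn1`: 152 ug/mL

Going by the values given here, in a physicochemical assay for solubility (on this read-out higher numbers stand for higher solubility and lower numbers for lower solubility), compound 1 gives 22 ug/mL, the lowest of the two numbers measured so far. Among the compounds with values here, its only neighbour is compound 2, which gives 152 ug/mL in this assay; the change was a 6.9-fold higher number from compound 1 to compound 2 (0.84 log units; beyond the scatter).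

Compound 3 `Cc1nc(Cn2c(=O)[nH]c3c(N)nc(C(F)(F)F)cc32)cs1` has not yet been measured. It differs from compound 1 in one place: 2-methyl-1,3-thiazol-4-yl in place of 6-methylpyridin-3-yl on a saturated chain carbon bound to an aromatic nitrogen.

Within the data shown here, the only step that bears on this change is the one from compound 1 to compound 2, where a different heteroaromatic ring entering at the same place gave a modest rise. The ring entering in compound 3 is not the same ring, so that step is only a rough guide. A small rise, or no change beyond the scatter, is expected for compound 3 in this assay, as a 1.6-fold higher number from compound 1 to compound 3 (0.20 log units; within the scatter). The estimate for compound 3 is therefore 35 ug/mL, with a range from 12 ug/mL to 100 ug/mL.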

Compound 3, solubility: 8 ug/mL
Estimate against measurement, compound 3: 4.4-fold (0.64 log units) above; the measured number lies below the stated range.
By their numbers in this assay, from the lowest: compound 3; then compound 1; then compound 2.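

In this assay, this position responds in both directions: the step to the 2-methylpyrimidin-5-yl group raised the number, yet placing 2-methyl-1,3-thiazol-4-yl on the same saturated chain carbon gives a 2.8-fold lower number from compound 1 to compound 3 (0.44 log units; beyond the scatter) and so lies on the opposite side of the 6-methylpyridin-3-yl group. Set against the 2-methylpyrimidin-5-yl group, the same change gives a 19-fold lower number from compound 2 to compound 3 (1.28 log units; beyond the scatter) and shows that the choice of aromatic ring alone spans a large range here. No measurement shown explains this order of the three rings.

The five-membered ring in compound 3 differs from the ring in compound 1 in both size and hetero atoms, and these two changes cannot be separated here. From the compounds shown here alone, how a ring bearing an amine or a carboxylic acid would behave at this place remains open.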